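The compounds below may be only part of what the source reports. "The series", "measured", "known", "first", "only" and "open" are said of these compounds alone.

In a functional assay on HeLa cells (Homo sapiens) for inhibition, read by MTT assay, with a stated time of 72 h (on this read-out lower numbers stand for stronger inhibition and higher numbers for weaker inhibition), compound 1 `Clc1ccc(Nc2nnc(-c3c[nH]c4ccccc34)o2)cc1` gives 3800 nM as its reading, with chloro on an aromatic carbon. Compound 2 `Fc1ccc(Nc2nnc(-c3c[nH]c4ccccc34)o2)cc1` shows > 100000 nM in this assay and that figure is a limit of the assay, not a number. So compound 2 has no exact position on the scale. Going by the values given here, exchanging chloro for fluoro gives an at least 26-fold higher number from compound 1 to compound 2 (1.42 log units; beyond the scatter) and this is the only measured step that bears on what follows.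

Compound 3 `Cc1ccc(Nc2nnc(-c3c[nH]c4ccccc34)o2)cc1` keeps the shared core and changes that same carbon again methyl in place of fluoro on an aromatic carbon so that methyl stands in place of fluoro, on a six-membered aromatic ring of carbon only, para to a large group. Among the compounds with values here, no measured step involves methyl, so any forecast is rough. Still, compound 1 shows 3800 nM as a reading that a group other than fluoro can give at this place, so a large move toward lower numbers is expected. The expected change is an at least 12-fold lower number from compound 2 to compound 3 (1.09 log units; beyond the scatter) as an estimate. For compound 3 the estimate is 8000 nM with an expected range from 1500 nM to 50000 nM as its spread.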

Compound 3, half-maximal inhibitory concentration: 15800 nM
Beside the measured number, compound 3's estimate is 2.0-fold (0.30 log units) below it; measured number inside the range.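

With methyl on this aromatic carbon, this assay gives an at least 6.3-fold lower number from compound 2 to compound 3 (0.80 log units; beyond the scatter), so a group with no halogen atom can also restore activity that fluoro does not show. The size of that step is only a minimum, and compound 2 stands at a limit of the assay, not a number: the limit of > 100000 nM in this assay, at which 1 of the 3 values shown sits. Methyl does not fully match chloro, however, as the change from chloro to methyl gives a 4.2-fold higher number from compound 1 to compound 3 (0.62 log units; beyond the scatter), which places the three groups in a clear order at this position, with chloro giving the lowest number, methyl the middle one and fluoro the limit.

Going by these compounds, three groups are too few to show what sets this order, so it remains open whether bromo, methoxy, an amine or a carboxylic acid on the same carbon would fall within it or outside it. On these data alone, it is also open whether a longer chain, such as ethyl, would move the number further toward that of compound 1 or back toward that of compound 2.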